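This account rests on a few compounds, and the source may have more. Where it says the series, first, only, none or still open, it means among the compounds named here.

Measured in a functional assay on HCT-116 cells (Homo sapiens) for antiproliferative activity, read by MTT assay, with a stated time of 72 h; a lower number here means a stronger inhibitor, a higher number a weaker inhibitor:
- Compound 1 `COc1ccc(/C=C2/CN(C)/C(=N/c3ccc(C(C)(C)C)cc3)S2)cc1`: 25900 nM
- Compound 2 `COc1ccc(/C=C2/CN(C)/C(=N/c3ccc(Br)cc3)S2)cc1`: 8900 nM
- Compound 3 `COc1ccc(/C=C2/CN(C)/C(=N/c3ccc(F)cc3)S2)cc1`: 10000 nM

These three compounds share one core and differ only in a single group on the aromatic ring. Compound 3, the fluoro member, sits at the lower end of this short series, level with the bromo member. Two steps place it: a 1.1-fold higher number from compound 2 to compound 3 (0.05 log units; within the scatter), and a 2.6-fold lower number from compound 1 to compound 3 (0.41 log units; beyond the scatter).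

The next structure is compound 4 `COc1ccc(/C=C2/CN(C)/C(=N/c3ccc([N+](=O)[O-])cc3)S2)cc1`, with nitro in place of fluoro on an aromatic carbon, para to a large group: nitro in place of fluoro on an aromatic carbon.

Within the data shown here, no measured compound carries a nitro group, so the evidence is indirect. The measured changes at this same place are small. Swapping one halogen for the other gave a 1.1-fold higher number from compound 2 to compound 3 (0.05 log units; within the scatter), and the largest change seen here, a 2.9-fold lower number from compound 1 to compound 2 (0.46 log units; beyond the scatter), is only modest. Three compounds are a thin basis, so a modest move in either direction remains possible. In this assay, no step beyond the scatter is therefore expected, and the expected step is a 1.1-fold lower number from compound 3 to compound 4 (0.05 log units; within the scatter). The estimated value for compound 4 is 9000 nM, within an expected range from 3500 nM to 24000 nM.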

Compound 4, half-maximal inhibitory concentration: 10200 nM
The estimate for compound 4 lay 1.1-fold (0.05 log units) below the measured number, and the stated range covers the measured number.
By their numbers in this assay, from the lowest: compounds 2, 3 and 4 (each within the scatter of the next); then compound 1.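

In this assay, nitro in place of fluoro gives a 1.0-fold higher number from compound 3 to compound 4 (0.01 log units; within the scatter) and nitro in place of bromo gives a 1.1-fold higher number from compound 2 to compound 4 (0.06 log units; within the scatter), so the level reached by the two halogens is shared by a group of a different kind. The earlier compounds shown here could not show this: they compared only fluoro and bromo within that level, whereas nitro brings three heavy atoms and two hydrogen-bond acceptors in place of the single heavy atom and no acceptors of fluoro, and still no step beyond the scatter appears at this place on the aromatic ring. Among the four compounds, only the tert-butyl member stands apart, with a 2.5-fold lower number from compound 1 to compound 4 (0.40 log units; beyond the scatter) as its step to the nitro member, and no accompanying measurement explains why the numbers fall this way.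

The compounds shown leave open whether an amine, a carboxylic acid or a hydroxyl group at this place would join the level of compounds 2, 3 and 4 or stand apart as tert-butyl does. They also leave open whether an isopropyl group, which is a smaller branched chain than tert-butyl, would sit with that level or with compound 1.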